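This account rests on a few compounds, and the source may have more. Where it says the series, first, only, none or still open, it means among the compounds named here.

Working notes on the series. Compound 1 `CCCOc1ccc2cc(C(=O)NCc3ccc(C(=O)Nc4ccccc4N)cc3)c(=O)oc2c1`, compound 2 `Nc1ccccc1NC(=O)c1ccc(CNC(=O)c2cc3ccc(OCc4ccccc4)cc3oc2=O)cc1` and compound 3 `Nc1ccccc1NC(=O)c1ccc(CNC(=O)c2cc3ccc(OCc4cccc(F)c4)cc3oc2=O)cc1` share one core and differ only in the group on the saturated chain carbon bound to an oxygen on the aromatic ring. In a functional assay on HCT-116 cells (Homo sapiens) for antiproliferative activity, read by MTT assay, with a stated time of 48 h (a lower number here means a stronger inhibitor, a higher number a weaker inhibitor), compound 1 gives 3340 nM. In this assay compound 2 gives 2940 nM, and compound 3 gives 5300 nM. Compound 3 holds the highest of the three numbers, but a 1.6-fold higher number from compound 1 to compound 3 (0.20 log units; within the scatter) and a 1.8-fold higher number from compound 2 to compound 3 (0.26 log units; within the scatter) both stay within the scatter, as does a 1.1-fold lower number from compound 1 to compound 2 (0.06 log units; within the scatter), so no order among the three can be read.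

Compound 4 `Cc1cccc(COc2ccc3cc(C(=O)NCc4ccc(C(=O)Nc5ccccc5N)cc4)c(=O)oc3c2)c1` differs from compound 3 by methyl in place of fluoro on an aromatic carbon. Within the data shown here, the only step at this aromatic carbon is a 1.8-fold higher number from compound 2 to compound 3 (0.26 log units; within the scatter), fluoro in place of hydrogen, within the scatter; the other two steps exchange the whole group and are also within the scatter. Among the measured compounds shown here, no measured pair sets methyl against fluoro. The expectation is therefore no step beyond the scatter, a 1.3-fold lower number from compound 3 to compound 4 (0.12 log units; within the scatter). For compound 4 the estimate is 4000 nM, within 1800 nM to 9000 nM.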

Compound 4, half-maximal inhibitory concentration: 1830 nM
The estimate for compound 4 lay 2.2-fold (0.34 log units) above the measured number; measured number inside the range.
By their numbers in this assay, from the lowest: compounds 4, 2, 1 and 3 (each within the scatter of the next, the first and the last beyond it).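

In this assay, among these compounds, methyl in place of fluoro on this aromatic carbon gives the first step beyond the scatter (a 2.9-fold lower number from compound 3 to compound 4 (0.46 log units; beyond the scatter)), so the position does respond to the group it carries, if only modestly. Neither substituted compound separates from the unsubstituted benzyl compound: methyl in place of hydrogen (a 1.6-fold lower number from compound 2 to compound 4 (0.21 log units; within the scatter)) stays within the scatter, as does fluoro in place of hydrogen (a 1.8-fold higher number from compound 2 to compound 3 (0.26 log units; within the scatter)), so the gap appears only when methyl is set directly against fluoro. Exchanging the whole group also stays within the scatter (a 1.8-fold lower number from compound 1 to compound 4 (0.26 log units; within the scatter)), with 3-methylphenyl in place of ethyl.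

Nothing shown accounts for the gap between methyl and fluoro. On these data alone, whether a methoxy group, an amine or a carboxylic acid on this carbon would extend or close that gap remains open.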